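Replacing the cycloheptyl amide of compound 1

The compounds below may be only part of what the source reports. "The series", "measured", "known", "first", "only" and "open" are said of these compounds alone.

The study concerns three measured amides sharing one core and a fourth that is not yet measured. Compound 1, with the structure `COc1cccc(OC)c1C(=O)Nc1c[nH]nc1C(=O)NC1CCCCCC1`, gives 42000 nM in an ADME assay on MRC5 cells (Homo sapiens) for inhibition, with a stated time of 72 h; a higher number here means that more compound is needed for the effect, a lower number that less compound is needed. Compound 2, `CO[C@H]1CC[C@H](NC(=O)c2n[nH]cc2NC(=O)c2ccc(-c3ccccc3)o2)CC1`, gives 100 nM in this assay, and compound 3, `CO[C@H]1CC[C@H](NC(=O)c2n[nH]cc2NC(=O)c2ccccc2)CC1`, gives 800 nM in this assay. Compound 1 thus stands at the highest number of the three; its nearest neighbour is compound 3, and compound 2 lies furthest from it, both separations reaching beyond the usual scatter.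

Compound 4, `COc1cccc(OC)c1C(=O)Nc1c[nH]nc1C(=O)NCCN1CCCC1`, differs from compound 1 in one place: 2-(pyrrolidin-1-yl)ethyl in place of cycloheptyl on an amide-type nitrogen. Among the compounds with values here, no measured pair in this set shows this change, so nothing here tells how large a step it brings. Absent such a precedent, compound 4 is expected to land near compound 1, with the step of a 1.4-fold lower number from compound 1 to compound 4 (0.15 log units; within the scatter) expected to stay within or only slightly beyond the scatter. Compound 4 is accordingly estimated at 30000 nM, with a range from 8000 nM to 100000 nM.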

Compound 4, half-maximal effective concentration: > 50000 nM
Compound 4 ended at the assay's limit (the forecaster's own chance of this, stated with the estimate: 20%); middle value at least 1.6-fold (0.22 log units) from the limit.
By their numbers in this assay, from the lowest: compound 2; then compound 3; then compound 1. At a limit, above all of these: compound 4.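

In this assay compound 4 gives > 50000 nM, and this value is a limit of the assay, not a number. Placing 2-(pyrrolidin-1-yl)ethyl in place of cycloheptyl on the amide-type nitrogen gives an at least 1.1-fold higher number from compound 1 to compound 4 (0.07 log units; that floor lies within the scatter), so this position now has a first step, and that step brought no lower number even though the entering group carries a ring nitrogen and a hydrogen-bond acceptor that cycloheptyl lacks. The true size of the step cannot be read, only its floor: the limit of > 50000 nM in this assay, at which 1 of the 4 values shown sits.

On these data alone, what a 2-(morpholin-4-yl)ethyl group, a plain cyclohexyl ring or a chain ending in a carboxylic acid would give on this nitrogen stays open. Also open, as far as these compounds go, is whether any group here could bring the number down while the rest of compound 1 stays unchanged.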